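The source may report more compounds than this note shows. Statements on the series, on what has been measured and on what is new or still open speak of the compounds shown alone.

Compound 2 `CC(C)[C@H](NC(=O)COc1cccc2ccccc12)C(=O)N[C@@H](CC(=O)O)C(=O)CSc1nnnn1C` carries a (1-methyl-1H-tetrazol-5-yl)sulfanyl group on a saturated chain carbon bound to a carbonyl carbon. In a functional assay on Jurkat cells (Homo sapiens) for inhibition (on this read-out lower numbers stand for stronger inhibition and higher numbers for weaker inhibition), compound 2 gives only a limit, > 200000 nM. Among the measured compounds shown here, its single measured neighbour is compound 1 `CC(C)[C@H](NC(=O)COc1cccc2ccccc12)C(=O)N[C@@H](CC(=O)O)C(=O)CSc1nccn1C`, which bears 1-methyl-1H-imidazol-2-yl on the sulfur instead. In this assay compound 1 likewise gives only a limit, > 200000 nM. The step that the two limits leave unreadable from compound 1 to compound 2 therefore cannot be read, and the limit of > 200000 nM in this assay, at which 2 of the 2 values shown sit, is all the series shows at this point. Compound 3 `CC(C)[C@H](NC(=O)COc1cccc2ccccc12)C(=O)N[C@@H](CC(=O)O)C(=O)COn1nnc2ccccc21` is not yet measured; it differs from compound 2 in a group of 10 heavy atoms (6 carbon, 3 nitrogen, 1 oxygen; one five-membered aromatic ring with 3 hetero atoms, one six-membered aromatic ring of carbon only) in place of a group of 7 heavy atoms (2 carbon, 4 nitrogen, 1 sulfur; one five-membered aromatic ring with 4 hetero atoms), on a saturated chain carbon bound to a carbonyl carbon. For the measured compounds named here, no measured step bears on this change: the only step known, from compound 1 to compound 2, sits between two limits and has no size. Nothing in the numbers shown points to a move beyond the scatter in either direction. Compound 3 is therefore expected to stay near the limit, estimated at 150000 nM in this assay, within 20000 nM to 800000 nM. The step this estimate implies, an at least 1.3-fold lower number from compound 2 to compound 3 (0.12 log units; that floor lies within the scatter), is expected to fall within the scatter, with a limit the most likely report.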

Compound 3, half-maximal inhibitory concentration: > 200000 nM
Compound 3: no number, only a limit (the forecaster's own chance of this, stated with the estimate: 70%); middle value at least 1.3-fold (0.12 log units) from the limit.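

In this assay compound 3 gives only a limit, > 200000 nM. The steps among compound 1, compound 2 and compound 3 therefore cannot be read, and the series shows only this: the limit of > 200000 nM in this assay, at which 3 of the 3 values shown sit. The compounds shown leave open whether any group on this saturated chain carbon bound to a carbonyl carbon gives a measurable inhibition value.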